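The source may report more compounds than this note shows. Statements on the series, on what has been measured and on what is new or still open speak of the compounds shown alone.

Measured compounds:
compound 1 `COc1ccccc1N1CCN(CC(=O)N2CCN(c3nnc(-c4ccccc4)c(-c4ccccc4)n3)CC2)CC1`, 444000 nM
compound 2 `O=C(CN1CCN(c2cccc(Cl)c2)CC1)N1CCN(c2nnc(-c3ccccc3)c(-c3ccccc3)n2)CC1`, 178000 nM
compound 3 `O=C(CN1CCN(c2ccc(Cl)cc2)CC1)N1CCN(c2nnc(-c3ccccc3)c(-c3ccccc3)n2)CC1`, 113000 nM

In an ADME assay on NIH3T3 cells (Mus musculus) for cytotoxicity, read by MTT assay, with a stated time of 24 h (a lower number here means a stronger inhibitor, a higher number a weaker inhibitor), compound 1 gives the highest of the three numbers, so it is the weakest of the measured set. Compound 4 `O=C(CN1CCN(c2ccc([N+](=O)[O-])cc2)CC1)N1CCN(c2nnc(-c3ccccc3)c(-c3ccccc3)n2)CC1` is not yet measured; it differs from compound 1 in one place: 4-nitrophenyl in place of 2-methoxyphenyl on an amine nitrogen in a ring. For the measured compounds named here, two measured steps bear on this change, both replacing the same 2-methoxyphenyl with a chlorophenyl: a 2.5-fold lower number from compound 1 to compound 2 (0.40 log units; beyond the scatter) and a 3.9-fold lower number from compound 1 to compound 3 (0.59 log units; beyond the scatter). The gap between the two chlorophenyl compounds, a 1.6-fold lower number from compound 2 to compound 3 (0.20 log units; within the scatter), is small. For compound 4 a similar modest move to a lower number in this assay is expected, a 3.0-fold lower number from compound 1 to compound 4 (0.47 log units; beyond the scatter). Compound 4 is estimated at 150000 nM, with a range from 60000 nM to 350000 nM.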

Compound 4, half-maximal inhibitory concentration: > 886000 nM
Compound 4: no number, only a limit; the forecaster's own chance of this, stated with the estimate: 15%; at least 5.9-fold (0.77 log units) between middle value and limit.
By their numbers in this assay, from the lowest: compounds 3 and 2 (each within the scatter of the next); then compound 1. At a limit, above all of these: compound 4.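

Compound 4 gives no number in this assay, only a limit: the limit of > 886000 nM in this assay, at which 1 of the 4 values shown sits. On the aromatic carbon of this phenyl ring, nitro in place of chloro separates compound 4 clearly from the chlorophenyl pair (an at least 7.8-fold higher number from compound 3 to compound 4 (0.89 log units; beyond the scatter); an at least 4.9-fold higher number from compound 2 to compound 4 (0.69 log units; beyond the scatter)), so the group on this ring can move the number far upward. Against compound 1 the floor is small (an at least 1.9-fold higher number from compound 1 to compound 4 (0.30 log units; that floor lies within the scatter)), so 4-nitrophenyl cannot be ranked firmly against 2-methoxyphenyl.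

On these data alone, the true value of compound 4 remains open. So does whether an amine or a nitrile in place of the nitro would fall with the chloro compounds or with compound 4.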